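This account rests on a few compounds, and the source may have more. Where it says the series, first, only, none or still open, it means among the compounds named here.

Compound 1 `CC(C)N(C(=O)CCNC(=O)c1ccc(S(C)(=O)=O)c([N+](=O)[O-])c1)C(C)C` in an assay on isolated protein for inhibition of thyroid hormone receptor alpha (Homo sapiens), read by fluorescence polarization (a lower number here means a stronger inhibitor, a higher number a weaker inhibitor), gives > 60000 nM, which is a limit of the assay and not a number.
Compound 2 `CC1CCN(C(=O)CCNC(=O)c2ccc(S(C)(=O)=O)c([N+](=O)[O-])c2)CC1` in this assay gives > 60000 nM, again a limit rather than a number.
Compound 3 `CS(=O)(=O)c1ccc(C(=O)NCCCC(=O)N2CCC(c3ccccc3)CC2)cc1[N+](=O)[O-]` in this assay gives > 60000 nM, also a limit.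

Compound 1 and compound 2 differ in one place only, yet their step that the two limits leave unreadable from compound 1 to compound 2 cannot be read, since both values are limits. Going by the values given here, compound 3 stands at the limit of > 60000 nM in this assay, at which 3 of the 3 values shown sit, and every value measured so far rests on that same limit, so no measured step shows a direction or a size.

Compound 4 `CS(=O)(=O)c1ccc(C(=O)NCCCC(=O)N2CCCCC2)cc1[N+](=O)[O-]` differs from compound 3 in one place: hydrogen in place of phenyl on a saturated ring carbon. Among the compounds with values here, no measured step speaks to this change. With compound 3 at a limit in this assay and nothing showing inhibition anywhere in the shared core, the expectation is that compound 4 also reaches only the limit in this assay. The step that the limit leaves unreadable from compound 3 to compound 4 is therefore expected to be none beyond the scatter. Compound 4 is estimated at 100000 nM, in a range from 30000 nM to 400000 nM.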

Compound 4, half-maximal inhibitory concentration: > 60000 nM
Compound 4: no number, only a limit (the forecaster's own chance of this, stated with the estimate: 90%); the middle value is on the limit's open side.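

Compound 4 also ends at a limit of the assay and not a number, so its steps from compound 1, compound 2 and compound 3 cannot be read: the limit of > 60000 nM in this assay, at which 4 of the 4 values shown sit.

The compounds shown leave open which change to the shared core, if any, would give a measurable value in this assay.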